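Varying the amide substituent in a frizzled-related protein binder

A few compounds are considered here, and "the series" means these few. Any claim that something is new, unique, unknown or untested is made for them only; others in the source may bear on it.

Compound 1 `O=C(c1ccc(Cl)cc1)N1CCC(NS(=O)(=O)c2cc(S(=O)(=O)c3ccccc3)ccc2C(F)(F)F)CC1`: in an assay on isolated protein for displacement of a labelled ligand from secreted frizzled-related protein 1 (Homo sapiens), read by fluorescence polarization, with a stated time of 30 min (on this read-out lower numbers stand for stronger inhibition and higher numbers for weaker inhibition), compound 1 gives 300 nM
Compound 2 `CN(C)c1ccc(C(=O)N2CCC(NS(=O)(=O)c3cc(S(=O)(=O)c4ccccc4)ccc3C(F)(F)F)CC2)cc1`: compound 2 gives 300 nM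
Compound 3 `CC(C)(O)CCN1CCC(NS(=O)(=O)c2cc(S(=O)(=O)c3ccccc3)ccc2C(F)(F)F)CC1`: compound 3 gives 200 nM

Compound 1 stands level with compound 2 at the digits shown, and together they hold the highest numbers of the three; the step from compound 1 to compound 3 is a 1.5-fold lower number from compound 1 to compound 3 (0.18 log units; within the scatter). Compound 4 `O=C(CC1CCNCC1)N1CCC(NS(=O)(=O)c2cc(S(=O)(=O)c3ccccc3)ccc2C(F)(F)F)CC1` is not yet measured. It differs from compound 1 in one place: (piperidin-4-yl)methyl in place of 4-chlorophenyl on a carbonyl carbon. Cut one bond further out, the same difference reads (4-chlorophenyl)carbonyl to ((piperidin-4-yl)methyl)carbonyl, so compound 4 keeps the carbonyl that compound 3 lacks.

Within the data shown here, two measured steps bear on this. no change at the digits printed from compound 1 to compound 2 (within the scatter) shows that the aromatic ring on that carbonyl tolerates a different substituent. a 1.5-fold lower number from compound 1 to compound 3 (0.18 log units; within the scatter) and a 1.5-fold lower number from compound 2 to compound 3 (0.18 log units; within the scatter) show that removing the acyl group altogether in favour of 3-hydroxy-3-methylbutyl leaves the number within the scatter. Neither speaks to a non-aromatic ring with a hydrogen-bond donor here, so only a small step is expected, a 1.2-fold lower number from compound 1 to compound 4 (0.08 log units; within the scatter). Compound 4 is therefore estimated at 250 nM, in the range 100 nM to 700 nM.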

Compound 4, half-maximal inhibitory concentration: 100 nM
Compound 4: middle estimate off by 2.5-fold (0.40 log units), on the high side; low and high end bracket the measured number.
By their numbers in this assay, from the lowest: compounds 4, 3, 1 and 2 (each within the scatter of the next, the first and the last beyond it).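

Among these compounds, exchanging the aromatic group on the carbonyl carbon for (piperidin-4-yl)methyl produces the only steps in this set that lie beyond the scatter, a 3.0-fold lower number from compound 1 to compound 4 (0.48 log units; beyond the scatter) and a 3.0-fold lower number from compound 2 to compound 4 (0.48 log units; beyond the scatter), whereas the earlier change of substituent on the aromatic ring left the number as it was. The position therefore responds to the group on the carbonyl carbon, although the comparison with the compound lacking that carbonyl stays within the scatter, at a 2.0-fold lower number from compound 3 to compound 4 (0.30 log units; within the scatter). No measurement available here accounts for the difference.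

The compounds shown do not separate the contribution of the ring nitrogen from that of the ring itself, a question a cyclohexylmethyl group on the same carbonyl carbon would address. A piperidin-4-yl group without the methyl link would likewise test whether that link matters.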